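A Trifluoromethyl Sulfonamide Variant and Its Expected Tolerance

The source may hold more compounds than are shown below. What is called first, only, known or untested is meant among the compounds shown, and "the series" means these compounds.

Compound 2 `Cc1cc(C#N)cc(C)c1Oc1nc(Nc2ccc(C#N)cc2)ncc1/C=C/C(=O)NC1CCN(S(C)(=O)=O)CC1` was tested in an ADME assay on TZM cells (Homo sapiens) for cytotoxicity, with a stated time of 1 days; a lower number here means that less compound is tolerated, a higher number that more compound is tolerated. In this assay compound 2 gives > 175 nM, which is a limit of the assay rather than a number. Its nearest measured neighbour, compound 1 `COCCNC(=O)/C=C/c1cnc(Nc2ccc(C#N)cc2)nc1Oc1c(C)cc(C#N)cc1C`, carries a 2-methoxyethyl on the amide-type nitrogen in place of the 1-(methylsulfonyl)piperidin-4-yl. In this assay compound 1 gives > 213 nM, again a limit. The step that the two limits leave unreadable from compound 1 to compound 2 is unreadable, since both values sit at limits the limit of > 175 nM in this assay, at which 1 of the 2 values shown sits (the limit of > 213 nM in this assay, at which 1 of the 2 values shown sits). Compound 3 `Cc1cc(C#N)cc(C)c1Oc1nc(Nc2ccc(C#N)cc2)ncc1/C=C/C(=O)NC1CCN(S(=O)(=O)C(F)(F)F)CC1` carries trifluoromethyl in place of methyl on a sulfonyl sulfur. Within the data shown here, no measured step touches the sulfonyl sulfur, and the single measured step gives no size, so the data offer no direction for this change. Compound 3 is expected to be tolerated to about the same degree as its measured neighbours, a step that the limit leaves unreadable from compound 2 to compound 3 within the scatter, with an estimate of 300 nM ranging from 100 nM to 2000 nM, probably again reported only as a limit.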

Compound 3, half-maximal cytotoxic concentration: > 160 nM
Compound 3: a limit, no number; the forecaster's own chance of this, stated with the estimate: 75%; the middle value does not contradict the limit.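

In this assay compound 3 gives > 160 nM, which is a limit and not a number. Compound 2 also sits at a limit, so no step can be read between compound 2 and compound 3. The compounds shown leave open whether trifluoromethyl in place of methyl on a sulfonyl sulfur shifts the tolerated concentration at all.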